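Replacing the sulfur-bearing group of compound 2

The compounds below may be only part of what the source reports. "The series", "measured", "known", "first", "only" and "open" are said of these compounds alone.

Values measured in a functional assay on KYSE-450 cells (Homo sapiens) for inhibition, read by CCK-8 assay, with a stated time of 48 h (on this read-out higher numbers stand for weaker inhibition and lower numbers for stronger inhibition), are:
- compound 1 `CCN1CCN(C(=S)SCC(=O)N(Cc2ccc(OC)cc2)c2cc(OC)c(OC)c(OC)c2)CC1` gives 3070 nM
- compound 2 `COc1ccc(CN(C(=O)CSC(=S)N2CCOCC2)c2cc(OC)c(OC)c(OC)c2)cc1` gives 7220 nM
- compound 3 `COc1ccc(CN(C(=O)CSC(=S)N2CCc3cc(OC)ccc32)c2cc(OC)c(OC)c(OC)c2)cc1` gives 10200 nM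

Compound 2 lies close to its neighbour, with a 1.4-fold higher number from compound 2 to compound 3 (0.15 log units; within the scatter), whereas a 2.4-fold higher number from compound 1 to compound 2 (0.37 log units; beyond the scatter) sets it apart from the third member of the set. Compound 4 `COc1ccc(CN(C(=O)CN2CCN(C(C)=O)CC2)c2cc(OC)c(OC)c(OC)c2)cc1` brings a larger change: a group of 9 heavy atoms (6 carbon, 2 nitrogen, 1 oxygen; one six-membered non-aromatic ring with 2 hetero atoms) in place of a group of 9 heavy atoms (5 carbon, 1 nitrogen, 1 oxygen, 2 sulfur; one six-membered non-aromatic ring with 2 hetero atoms), on a saturated chain carbon bound to a carbonyl carbon. The measured steps only swap the group on a thiocarbonyl carbon, reaching a 3.3-fold higher number from compound 1 to compound 3 (0.52 log units; beyond the scatter), so they guide this new change only loosely. Within the data shown here, compound 4 has no direct precedent here, and a modest move towards a higher number in this assay is expected. The expected change is a 2.2-fold higher number from compound 2 to compound 4 (0.35 log units; beyond the scatter). The estimate for compound 4 is 16000 nM, with an expected range from 5000 nM to 50000 nM.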

Compound 4, half-maximal inhibitory concentration: 10800 nM
The estimate for compound 4 lay 1.5-fold (0.17 log units) above the measured number; measured number inside the range.
By their numbers in this assay, from the lowest: compound 1; then compounds 2, 3 and 4 (each within the scatter of the next).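

In this assay, a link without sulfur, with 4-acetylpiperazin-1-yl on a saturated chain carbon bound to a carbonyl carbon, gives a 1.5-fold higher number from compound 2 to compound 4 (0.17 log units; within the scatter), so this position tolerates losing both sulfur atoms with no clear shift from compound 2. The other step, a 3.5-fold higher number from compound 1 to compound 4 (0.55 log units; beyond the scatter), leaves compound 1 apart from the rest. No measurement shown here accounts for either step. Open, from the compounds shown here alone, is what 4-ethylpiperazin-1-yl would do placed directly on that chain carbon. That compound would show whether the edge of compound 1 survives without the sulfur-bearing link.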